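The source may hold more compounds than are shown below. What is called first, only, known or untested is meant among the compounds shown, and "the series" means these compounds.

Compound 3 `C=C(C)C(=O)c1ccc(OCCCN2CCN(C(=O)OCC)CC2)cc1` gives 22400 nM in an assay on isolated protein for binding affinity to histamine H2 receptor (Homo sapiens); on this read-out lower numbers stand for stronger inhibition and higher numbers for weaker inhibition. Among the three measured compounds it holds the second highest number: compound 1 `CCCCCC(=O)c1ccc(OCCCN2CCN(C(=O)N3CCOCC3)CC2)cc1` gives 17800 nM, a gap within the scatter, while compound 2 `CCOC(=O)N1CCN(CCCOc2ccc(C(=O)C3CC3)cc2)CC1` gives 79400 nM, a gap beyond the scatter. Compound 4 `CCOC(=O)N1CCN(CCCOc2ccc(C(=O)c3ccc(C(C)(C)C)cc3)cc2)CC1` differs from compound 3 in one place: 4-(tert-butyl)phenyl in place of 1-methylethenyl on a carbonyl carbon. Among the compounds with values here, this is the same place where compound 2 and compound 3 differ, and that step, a 3.5-fold lower number from compound 2 to compound 3 (0.55 log units; beyond the scatter), is the only measured step there; it is modest in size. Within the data shown here, no measured step swaps a small group for a 4-(tert-butyl)phenyl group, so the direction of the present change is uncertain. Because a 3.5-fold lower number from compound 2 to compound 3 (0.55 log units; beyond the scatter) was modest, the step of a 1.5-fold lower number from compound 3 to compound 4 (0.17 log units; within the scatter) is expected to be of similar or somewhat larger size, with a lower number thought a little more likely than a higher one. Compound 4 is therefore estimated at 15000 nM, with a range from 4000 nM to 60000 nM.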

Compound 4, inhibition constant: 1550 nM
For compound 4 the middle estimate is 9.7-fold (0.99 log units) above the measured one, and the stated range ends above it.
By their numbers in this assay, from the lowest: compound 4; then compounds 1 and 3 (each within the scatter of the next); then compound 2.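

The carbonyl carbon that held only small groups also accepts a far larger one: in this assay the 4-(tert-butyl)phenyl group brings a 14-fold lower number from compound 3 to compound 4 (1.16 log units; beyond the scatter) and a 51-fold lower number from compound 2 to compound 4 (1.71 log units; beyond the scatter), both large steps, whereas swapping one small group for the other brought only a 3.5-fold lower number from compound 2 to compound 3 (0.55 log units; beyond the scatter). Within the data shown here, this position is therefore not confined to small groups, and 10 heavy atoms with an aromatic ring, in place of 3 and no ring, mark the clearest change so far. Nothing available here explains why the number falls so far.

As far as these compounds go, it remains open whether the aromatic ring itself or the tert-butyl group on it accounts for the step, a question that a plain phenyl group would help to settle. From the compounds shown here alone, whether an amine or a carboxylic acid on that ring would fare as well also remains open.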